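Ethylsulfonyl in Place of Methylsulfonyl: Cytotoxicity Outlook

The compounds below may be only part of what the source reports. "The series", "measured", "known", "first", "only" and "open" are said of these compounds alone.

Measured compounds, in an ADME assay on HEK293 cells (Homo sapiens) for cytotoxicity, read by MTT assay, with a stated time of 48 h; a higher number here means a weaker inhibitor, a lower number a stronger inhibitor:
Compound 1 `Cc1cc(NC(=O)c2ccc(C#N)cc2)ccc1NS(C)(=O)=O` gives 43500 nM.
Compound 2 `CCS(=O)(=O)Nc1ccc(NC(=O)c2ccc(C#N)cc2)cc1C` gives only a limit of the assay, > 250000 nM.
Compound 3 `COc1cc(NC(=O)c2ccc(Cl)cc2)ccc1NS(C)(=O)=O` gives only a limit of the assay, > 250000 nM.

From compound 1 to compound 2 the change is methyl in place of hydrogen on a saturated chain carbon bound to a sulfonyl sulfur, and it made an at least 5.7-fold higher number from compound 1 to compound 2 (0.75 log units; beyond the scatter). Compound 4 `CCS(=O)(=O)Nc1ccc(NC(=O)c2ccc(Cl)cc2)cc1OC` is not yet measured; it carries the same change relative to compound 3, (methyl in place of hydrogen on a saturated chain carbon bound to a sulfonyl sulfur). The difference between the cores of compound 1 and compound 3 is not broken down here. Compound 3 already sits at the limit of > 250000 nM in this assay, at which 2 of the 3 values shown sit, so the earlier step cannot be reproduced as a number. Compound 4 is therefore expected to remain at the limit, with an estimate of 300000 nM. The expected step is a step that the limit leaves unreadable from compound 3 to compound 4, resting on compound 3 being at the limit and on the earlier step weakening cytotoxicity.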

Compound 4, half-maximal inhibitory concentration: > 250000 nM
Compound 4 was reported as a limit; the forecaster's own chance of this, stated with the estimate: 90%; the middle value does not contradict the limit.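

Compound 3 and compound 4 both give only a limit in this assay, not a number, so no step between them can be read: the limit of > 250000 nM in this assay, at which 3 of the 4 values shown sit.

The compounds shown leave open whether methylsulfonyl to ethylsulfonyl changes cytotoxicity at all on the core of compound 3.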